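This account rests on a few compounds, and the source may have more. Where it says the series, first, only, none or still open, it means among the compounds named here.

Two compounds share a thiourea carbonyl linkage on a bicyclic core and have been tested in an ADME assay on Huh-7 cells (Homo sapiens) for cytotoxicity; on this read-out higher numbers stand for lower toxicity in this test and lower numbers for higher toxicity in this test. Compound 1 `O=C(NC(=S)N1CCc2cc(OCc3ccccc3)ccc21)c1ccccc1` carries a benzyloxy substituent on the core and an unsubstituted benzoyl group; in this assay compound 1 gives 45200 nM. Compound 2 `O=C(NC(=S)N1CCc2c(OCCCCCOc3ccc(Cl)cc3)cccc21)c1ccc([N+](=O)[O-])cc1` carries instead the longer 4-chlorophenoxy-pentyloxy chain on the core and a 4-nitrophenyl carbonyl group; in this assay compound 2 gives 13600 nM. Among the two numbers, compound 2 stands lowest, with compound 1 at a higher value that lies beyond the usual scatter; since the two structures differ in more than one place, the pair shows only that much.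

Compound 3 `Cc1ccc(C(=O)NC(=S)N2CCc3c(OCCCCCOc4ccc(Cl)cc4)cccc32)cc1` keeps the core and chain of compound 2 and differs in one place: methyl in place of nitro on an aromatic carbon. For the measured compounds named here, no measured pair isolates this change, so nothing in the data sets its size. The step is expected to be small, within the scatter or only just beyond it, in either direction, as a 1.5-fold higher number from compound 2 to compound 3 (0.17 log units; within the scatter). Compound 3 is therefore estimated at 20000 nM, with a range from 6000 nM to 60000 nM.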

Compound 3, half-maximal cytotoxic concentration: > 50000 nM
Compound 3 was reported as a limit; the forecaster's own chance of this, stated with the estimate: 20%; middle value at least 2.5-fold (0.39 log units) from the limit.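

For the compounds shown here, with the core and the chain held fixed, methyl in place of nitro on an aromatic carbon, para to a large group, gives the first single-place step in this assay: an at least 3.6-fold higher number from compound 2 to compound 3 (0.56 log units; beyond the scatter). This shows that the group at this position can move the read-out, with the 4-nitrophenyl compound showing higher toxicity in this test than its 4-methylphenyl partner, something the pair of compound 1 and compound 2 could not show, since those two differ in more than one place. As far as these compounds go, compound 3 gives > 50000 nM, which is a limit of the assay and not a number, and the step built on it stays open at its upper end: the limit of > 50000 nM in this assay, at which 1 of the 3 values shown sits.

The compounds shown leave open whether the step follows the departure of nitro or the arrival of methyl, which a plain hydrogen, a chlorine or an amine at the same carbon would help to separate. Also open, from the compounds shown here alone, is whether nitro and methyl would differ this much with the benzyloxy group of compound 1 or a shorter chain on the core.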